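Removing the Amino Group from Compound 2's Pyridine

A few compounds are considered here, and "the series" means these few. Any claim that something is new, unique, unknown or untested is made for them only; others in the source may bear on it.

For the measured compounds named here, compound 2 `Nc1cc(-c2nc(C(c3ccc(F)cc3)c3ccc(F)cc3)sc2CC(=O)O)cc(F)n1` gives 30% in an in vitro functional assay on HEK285-7 cells for antagonist activity at prostaglandin D2 receptor 2 (Homo sapiens), read by BRET and beta-arrestin recruitment (a lower number here means a smaller maximal response, a higher number a larger maximal response), the lowest of the two numbers measured so far; its nearest neighbour, compound 1 `NS(=O)(=O)c1ccc(-c2nc(C(c3ccc(F)cc3)c3ccc(F)cc3)sc2CC(=O)O)cc1`, gives 80% in this assay. Going by the values given here, the one measured step, a number 50 percentage points lower from compound 1 to compound 2 (beyond the scatter), replaces the whole 4-sulfamoylphenyl by 2-amino-6-fluoropyridin-4-yl and so does not isolate the amino group.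

Compound 3 `O=C(O)Cc1sc(C(c2ccc(F)cc2)c2ccc(F)cc2)nc1-c1ccnc(F)c1` differs from compound 2 in a single place: hydrogen in place of amino on an aromatic carbon. Among the compounds with values here, no measured step removes an amino on its own, so the direction of the step in this assay is not fixed by the data; the large fall seen in a number 50 percentage points lower from compound 1 to compound 2 (beyond the scatter) shows only that this part of the molecule matters for the maximal response. Compound 3 is therefore expected to give 40% in this assay, within 15% to 70%, a step of a number 10 percentage points higher from compound 2 to compound 3 (within the scatter) that is estimated to stay close to the scatter.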

Compound 3, largest response reached (reported as efficacy), in percent of the reference or control that the assay uses: 80%
Estimate against measurement, compound 3: 40 percentage points below; the whole stated range lies below it.
By their numbers in this assay, from the lowest: compound 2; then compounds 1 and 3 (each within the scatter of the next).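

In this assay, the amino group on the aromatic carbon next to the ring nitrogen is now isolated as a single change: with hydrogen in its place, the result is a number 50 percentage points higher from compound 2 to compound 3 (beyond the scatter). The 2-fluoropyridin-4-yl of compound 3 and the 4-sulfamoylphenyl of compound 1 read alike, with no change at the digits printed from compound 1 to compound 3 (within the scatter), so the low maximal response of compound 2 goes with the amino group and not with the pyridine that replaces 4-sulfamoylphenyl. Nothing at hand gives a reason for this step.

The compounds shown leave open whether the amino group is alone in lowering the response at this carbon, or whether a methylamino, hydroxyl or methoxy group there would do the same. They also leave open what the fluoro group contributes to the step.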